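The source may report more compounds than this note shows. Statements on the series, on what has been measured and on what is new or still open speak of the compounds shown alone.

Measured so far in a functional assay on PC-3 cells (Homo sapiens) for cytotoxicity, read by sulforhodamine B assay, with a stated time of 48 h; a higher number here means a weaker inhibitor, a lower number a stronger inhibitor:
Compound 1 `C[C@H]1CC[C@@H]2[C@@H](OC(=O)[C@]23CC(c2ccc([N+](=O)[O-])cc2)=NO3)[C@]2(C)C(=O)C=C[C@@]12O` gives 12000 nM
Compound 2 `C[C@H]1CC[C@@H]2[C@@H](OC(=O)[C@]23CC(c2ccc(F)cc2)=NO3)[C@]2(C)C(=O)C=C[C@@]12O` gives 27000 nM

Of the two, compound 2 has the higher number and so is the weaker inhibitor of the pair. Compound 3 `C[C@H]1CC[C@@H]2[C@@H](OC(=O)[C@]23CC(c2ccc(C#N)cc2)=NO3)[C@]2(C)C(=O)C=C[C@@]12O` differs from compound 2 in one place (cyano in place of fluoro on an aromatic carbon), with cyano in place of fluoro on an aromatic carbon, para to a large group. Among the compounds with values here, one measured step bears on this place (a 2.3-fold higher number from compound 1 to compound 2 (0.35 log units; beyond the scatter)), and it is modest. It involves nitro, not cyano, so it is only an indirect guide. The compound without fluoro there, compound 1 (12000 nM), has the lower number. In this assay a step toward a lower number is therefore expected, no larger than that one and perhaps not beyond the scatter (a 1.6-fold lower number from compound 2 to compound 3 (0.20 log units; within the scatter)). Compound 3 is estimated at 17000 nM (expected range 8000 nM to 35000 nM).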

Compound 3, half-maximal inhibitory concentration: 32000 nM
Compound 3: the middle estimate sits 1.9-fold (0.27 log units) below what was measured, within the range that was stated.
By their numbers in this assay, from the lowest: compound 1; then compounds 2 and 3 (each within the scatter of the next).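

In this assay, cyano in place of fluoro on this aromatic carbon, para to a large group, gives a 1.2-fold higher number from compound 2 to compound 3 (0.07 log units; within the scatter) and so does not separate the two groups. Nitro at the same place does stand apart, with a 2.7-fold higher number from compound 1 to compound 3 (0.43 log units; beyond the scatter) as well as the step from nitro to fluoro, so the lower number of compound 1 is not shared by the cyano compound, which the first pair alone could not show. Nothing measured here explains why nitro differs from cyano at this place.

Still open, going by these compounds, is whether an amine, a methoxy group or a carboxylic acid at this place would give a number higher or lower than that of compound 1, which gives 12000 nM in this assay. The compounds shown also say nothing about changes elsewhere on the shared core, since all three differ only at this one position.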